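Compound 3 to compound 4: furan-2-yl for phenyl

This account rests on a few compounds, and the source may have more. Where it says the series, first, only, none or still open, it means among the compounds named here.

In a functional assay on THP-1 cells (Homo sapiens) for inhibition, read by sulforhodamine B assay, with a stated time of 48 h, tested at 50 uM (a higher number here means more inhibition of growth at the concentration tested, a lower number less inhibition of growth), compound 3 `COc1cc(/C=C/C(=O)/C=C/c2ccccc2)ccc1OCc1cn(CCCCCOc2cc(=O)oc3ccccc23)nn1` gives 26%. Compound 2 `COc1cc(/C=C/C(=O)/C=C/c2cccs2)ccc1OCc1cn(CCCCCOc2cc(=O)oc3ccccc23)nn1` gives 34%, within the scatter of compound 3. Among the measured compounds shown here, compound 1 `COc1ccc(/C=C/C(=O)/C=C/c2ccc(OCc3cn(CCCCCOc4cc(=O)oc5ccccc45)nn3)c(OC)c2)cc1OC` gives 47%, the only value clear of compound 3.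

Compound 4 `COc1cc(/C=C/C(=O)/C=C/c2ccco2)ccc1OCc1cn(CCCCCOc2cc(=O)oc3ccccc23)nn1` carries furan-2-yl in place of phenyl on a double-bonded chain carbon bound to a double-bonded chain carbon. For the measured compounds named here, the closest precedent is the exchange of thiophen-2-yl and phenyl, a number 8 percentage points lower from compound 2 to compound 3 (within the scatter). The larger steps, a number 13 percentage points lower from compound 1 to compound 2 (beyond the scatter) and a number 21 percentage points lower from compound 1 to compound 3 (beyond the scatter), both remove 3,4-dimethoxyphenyl, which this change leaves out of play. No step beyond the scatter is therefore expected, and the estimated step is a number 4 percentage points higher from compound 3 to compound 4 (within the scatter). The estimate for compound 4 is 30%, with an expected range of 18% to 43%.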

Compound 4, percent growth inhibition at one concentration: 39%
For compound 4 the middle estimate is 9 percentage points below the measured one; measured number inside the range.
By their numbers in this assay, from the lowest: compounds 3, 2, 4 and 1 (each within the scatter of the next, the first and the last beyond it).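

In this assay, the step of a number 13 percentage points higher from compound 3 to compound 4 (beyond the scatter) shows that exchanging one ring free of methoxy groups for another at this position can move the number beyond the scatter, which the exchange of thiophen-2-yl and phenyl did not show. Furan-2-yl does not separate from the other two groups, with the step of a number 5 percentage points higher from compound 2 to compound 4 (within the scatter) and the step of a number 8 percentage points lower from compound 1 to compound 4 (within the scatter). No available data explain the effect of the furan-2-yl ring. Going by these compounds, whether pyridin-2-yl or 4-methoxyphenyl at this place would separate from furan-2-yl remains open.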